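The source may hold more compounds than are shown below. What is called first, only, known or untested is meant among the compounds shown, and "the series" means these compounds.

Measured so far in a functional assay on M21 cells (Homo sapiens) for antiproliferative activity, read by sulforhodamine B assay, with a stated time of 48 h; on this read-out higher numbers stand for weaker inhibition and lower numbers for stronger inhibition:

compound 1 `CN1CCN(c2ccc(S(=O)(=O)Oc3cccc(Br)c3)cc2)C1=O`: 1300 nM.
compound 2 `CCCN1CCN(c2ccc(S(=O)(=O)Oc3cc(OC)cc(OC)c3)cc2)C1=O`: 33000 nM.
compound 3 `CCCCN1CCN(c2ccc(S(=O)(=O)Oc3ccccc3)cc2)C1=O`: > 100000 nM.

Compound 3 has no exact number to its name. Compound 3 reads > 100000 nM, which is only a limit of this assay.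

The next compound, compound 4 `CCCCN1CCN(c2ccc(S(=O)(=O)Oc3cc(F)cc(F)c3)cc2)C1=O`, has 3,5-difluorophenyl in place of phenyl on an oxygen, whose other neighbour is the sulfonyl sulfur: 3,5-difluorophenyl in place of phenyl on an oxygen.

For the measured compounds named here, no measured pair of compounds isolates this change, so any forecast rests on indirect comparison. Compound 1, at 1300 nM, and compound 2, at 33000 nM, both give real numbers with a group other than phenyl on that oxygen, although they also differ from compound 3 elsewhere. On that thin basis, the expectation is a move towards stronger inhibition, meaning a lower number, but not a dramatic one. The estimated change is an at least 5.0-fold lower number from compound 3 to compound 4 (0.69 log units; beyond the scatter), and its size is uncertain because the starting point is not an exact number. A result at the limit again would not be surprising. The estimated value for compound 4 is 20000 nM, with an expected range from 3000 nM to 100000 nM.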

Compound 4, half-maximal inhibitory concentration: > 100000 nM
Compound 4 ended at the assay's limit; the forecaster's own chance of this, stated with the estimate: 25%; middle value at least 5.0-fold (0.69 log units) away from the limit.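

Compound 4 reads > 100000 nM, which is a limit of this assay and not an exact number. Compound 3 reads > 100000 nM, also a limit. For the compounds shown here, no step can therefore be read between compound 3 and compound 4: the limit of > 100000 nM in this assay, at which 2 of the 4 values shown sit. The compounds shown leave open whether 3,5-difluorophenyl in place of phenyl changes inhibition at all.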